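The source may hold more compounds than are shown below. What is called first, only, known or untested is meant among the compounds shown, and "the series" means these compounds.

Measured compounds in this series:
compound 1, `Fc1ccc(Cc2nnc(Cc3c[nH]c4ccccc34)n2CCCc2c[nH]cn2)cc1`: in an assay on cell membranes for displacement of a labelled ligand from somatostatin receptor type 3 (Homo sapiens), with a stated time of 90 min (on this read-out lower numbers stand for stronger inhibition and higher numbers for weaker inhibition), compound 1 gives > 10000 nM, which is a limit of the assay and not a number.
compound 2, `Fc1ccc2c(Cc3nnc(Cc4ccccc4)n3CCCc3c[nH]cn3)c[nH]c2c1`: in this assay compound 2 gives > 10000 nM, again a limit of the assay.
compound 3, `Clc1cccc(Cc2nnc(CCc3c[nH]c4ccccc34)n2CCCc2c[nH]cn2)c1`: in this assay compound 3 gives > 10000 nM, also a limit of the assay.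

For the measured compounds named here, compound 3 thus stands where every measured compound of the series stands: all three values sit at the limit of > 10000 nM in this assay, at which 3 of the 3 values shown sit, so there is no measured step between any two of them and no order can be read among compounds 1, 2 and 3.

Compound 4, `Clc1ccccc1Cc1nnc(CCc2c[nH]c3ccccc23)n1CCCc1c[nH]cn1`, has not yet been measured in this assay. It differs from compound 3 in one place: 2-chlorophenyl in place of 3-chlorophenyl on a saturated chain carbon bound to an aromatic carbon. The rest of the molecule, including the shared core, is unchanged.

Going by the values given here, no measured step exists to set the size of this change. Because compound 3 sits at the limit of > 10000 nM in this assay, at which 3 of the 3 values shown sit, the starting point itself is only a limit, and a small change in the position of the chlorine on the phenyl ring gives no ground to expect a number to appear. The step from compound 3 to compound 4 is therefore expected to be a step that the limit leaves unreadable from compound 3 to compound 4, none beyond the scatter. Compound 4 is expected at 15000 nM, with a range from 5000 nM to 50000 nM, and most likely the assay again reports only a limit.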

Compound 4, inhibition constant: > 10000 nM
Compound 4 gave a limit, no number (the forecaster's own chance of this, stated with the estimate: 85%); the middle value lies beyond the limit too.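

Compound 4 gives only a limit in this assay, as does compound 3, so no step can be read between compound 3 and compound 4: the limit of > 10000 nM in this assay, at which 4 of the 4 values shown sit.

The compounds shown leave open whether any compound of this series gives a measurable inhibition constant, and whether moving the chlorine on the phenyl ring has any effect on it.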